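Swapping the aryl group on the urea of compound 3

This account rests on a few compounds, and the source may have more. Where it says the series, first, only, none or still open, it means among the compounds named here.

Measured so far in an ADME assay on WI-38 cells (Homo sapiens) for cytotoxicity, read by MTT assay, with a stated time of 72 h; a higher number here means a weaker inhibitor, a lower number a stronger inhibitor:
compound 1, `Cn1cnnc1-c1cc(Oc2ccc(NC(=O)Nc3cccc(C(F)(F)F)c3)cc2F)ccn1`, gives 12600 nM
compound 2, `CN(C)CCn1cnnc1-c1cc(Oc2ccc(NC(=O)Nc3cccc(C(F)(F)F)c3)cc2F)ccn1`, gives 11200 nM
compound 3, `CCN(CC)CCn1cnnc1-c1cc(Oc2ccc(NC(=O)Nc3cccc(C(F)(F)F)c3)cc2F)ccn1`, gives 6920 nM

The three measured compounds share one core and differ only on the saturated chain bound to an aromatic nitrogen. In this assay the steps are small: a 1.1-fold lower number from compound 1 to compound 2 (0.05 log units; within the scatter), a 1.8-fold lower number from compound 1 to compound 3 (0.26 log units; within the scatter) and a 1.6-fold lower number from compound 2 to compound 3 (0.21 log units; within the scatter). Compound 3 therefore sits within the scatter of both compound 1 and compound 2, and nothing in this set separates the three.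

Compound 4, `CCN(CC)CCn1cnnc1-c1cc(Oc2ccc(NC(=O)Nc3ccc(Cl)cc3Cl)cc2F)ccn1`, keeps the diethylamino chain of compound 3 and changes the other end of the molecule: 2,4-dichlorophenyl in place of 3-(trifluoromethyl)phenyl on an amide-type nitrogen. Within the data shown here, none of the measured steps touches this position, so no measured step bears directly on the change; the only guidance is that every change seen so far in this assay stayed within the scatter. On that basis the expected step of a 1.1-fold higher number from compound 3 to compound 4 (0.03 log units; within the scatter) is none beyond the scatter, and compound 4 is estimated at 7500 nM, within the range 2500 nM to 22000 nM.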

Compound 4, half-maximal inhibitory concentration: 4280 nM
Estimate against measurement, compound 4: 1.8-fold (0.24 log units) above; low and high end bracket the measured number.
By their numbers in this assay, from the lowest: compounds 4, 3, 2 and 1 (each within the scatter of the next, the first and the last beyond it).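

Compound 4 is the only compound shown that varies the aryl group on the amide-type nitrogen, so it gives the only view of this position; the earlier compounds differ only on the chain at the other end of the molecule. In this assay, placing 2,4-dichlorophenyl where 3-(trifluoromethyl)phenyl stood gives a 1.6-fold lower number from compound 3 to compound 4 (0.21 log units; within the scatter), so this exchange, like the chain changes, does not separate its two compounds. Nothing shown explains the step or links it to any feature of either group.

From the compounds shown here alone, whether a different group on this nitrogen, such as plain phenyl or a phenyl carrying a nitrile or a carboxylic acid, would move the number beyond the scatter remains open. Also open, going by these compounds, is how 2,4-dichlorophenyl would read with the chains of compound 1 and compound 2.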